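The source may report more compounds than this note shows. Statements on the series, on what has been measured and on what is new or still open speak of the compounds shown alone.

Measured so far in a functional assay on BGC-823 cells (Homo sapiens) for cytotoxicity, read by MTT assay; a lower number here means a stronger inhibitor, a higher number a weaker inhibitor:
compound 1 `Cc1nc(Nc2ccccc2)sc1C(=O)/C=C/c1ccc(Cl)cc1` gives > 25000 nM
compound 2 `Cc1ccc(Nc2nc(C)c(C(=O)/C=C/c3ccc(Cl)cc3)s2)cc1` gives > 25000 nM
compound 3 `COc1cc(/C=C/C(=O)c2sc(Nc3ccccc3)nc2C)cc(OC)c1OC` gives > 25000 nM

The value of compound 1 is a limit of the assay, not a number. The same holds for compound 2. The same holds for compound 3. All three rest at the limit of > 25000 nM in this assay, at which 3 of the 3 values shown sit. The change from compound 1 to compound 2 is methyl in place of hydrogen on an aromatic carbon, and a step that the two limits leave unreadable from compound 1 to compound 2. How the core of compound 1 and the core of compound 3 differ is not broken down here.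

Compound 4 `COc1cc(/C=C/C(=O)c2sc(Nc3ccc(C)cc3)nc2C)cc(OC)c1OC` carries the same change against compound 3: methyl in place of hydrogen on an aromatic carbon. The place is the same in both pairs. Because a step that the two limits leave unreadable from compound 1 to compound 2, and because the three values sit at the limit of > 25000 nM in this assay, at which 3 of the 3 values shown sit, compound 4 is expected to report a limit as well. The expected step is a step that the limit leaves unreadable from compound 3 to compound 4. For compound 4 the estimate is 40000 nM, with a range from 15000 nM to 120000 nM.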

Compound 4, half-maximal inhibitory concentration: > 25000 nM
Compound 4: no number, only a limit; the forecaster's own chance of this, stated with the estimate: 80%; the middle value lies beyond the limit too.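

The step between compound 3 and compound 4 cannot be read in this assay, because both values are limits and not numbers: the limit of > 25000 nM in this assay, at which 4 of the 4 values shown sit.

The compounds shown leave open whether phenyl to 4-methylphenyl changes the potency at all.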